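Amide Substituent Change on a Vitamin D Receptor Agonist Series

The source may hold more compounds than are shown below. What is called first, only, known or untested is meant among the compounds shown, and "the series" means these compounds.

Compound 1, `C#CCNC(=O)c1ccc(C(CC)(CC)c2ccc(OCC(=O)C(C)(C)C)c(C)c2)n1CC`, gives 2200 nM in an assay on HL-60 cells for agonist activity at vitamin D3 receptor (Homo sapiens), read by microscopy, with a stated time of 96 h; a higher number here means that more compound is needed for the effect, a lower number that less compound is needed. Compound 2, `CCn1c(C(=O)NCCN)ccc1C(CC)(CC)c1ccc(OCC(=O)C(C)(C)C)c(C)c1`, gives 120 nM. Compound 3, `CCn1c(C(=O)NCCN)ccc1C(CC)(CC)c1ccc(OCC(O)C(C)(C)C)c(C)c1`, gives 10 nM.

Compound 3 holds the lowest number of the three measured compounds. Its nearest neighbour is compound 2, which is separated from it by a 12-fold lower number from compound 2 to compound 3 (1.08 log units; beyond the scatter), and compound 1 lies further off, the two being linked through compound 2 by an 18-fold lower number from compound 1 to compound 2 (1.26 log units; beyond the scatter).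

Compound 4, `CCn1c(C(=O)Nc2ccc(OC(F)(F)F)cc2)ccc1C(CC)(CC)c1ccc(OCC(O)C(C)(C)C)c(C)c1`, is made from compound 3 by 4-(trifluoromethoxy)phenyl in place of 2-aminoethyl on an amide-type nitrogen. Going by the values given here, of the two measured steps, only the one from compound 1 to compound 2 touches the same amide-type nitrogen, and there an 18-fold lower number from compound 1 to compound 2 (1.26 log units; beyond the scatter) shows that what sits on that nitrogen can move the number a long way. The step from compound 2 to compound 3 concerns the other end of the molecule and does not bear on the present change. No measured compound carries an aromatic group on the amide-type nitrogen, so the direction cannot be read from the shown data; a step beyond the scatter in either direction is possible. Weighing the size seen in an 18-fold lower number from compound 1 to compound 2 (1.26 log units; beyond the scatter), compound 4 is expected to give about 30 nM, with a range from 5 nM to 200 nM, that is a step of a 3.0-fold higher number from compound 3 to compound 4 (0.48 log units; beyond the scatter) from compound 3.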

Compound 4, half-maximal effective concentration: > 50000 nM
Compound 4: a limit, no number (the forecaster's own chance of this, stated with the estimate: 5%); middle value at least 1600-fold (3.22 log units) away from the limit.
By their numbers in this assay, from the lowest: compound 3; then compound 2; then compound 1. At a limit, above all of these: compound 4.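

The new step shows that a group on the amide-type nitrogen can do far more than lower the number: an at least 5000-fold higher number from compound 3 to compound 4 (3.69 log units; beyond the scatter) in this assay is a larger move than any earlier step. It also points the same way as an 18-fold lower number from compound 1 to compound 2 (1.26 log units; beyond the scatter), since 2-aminoethyl is the group that enters there and the group that leaves here, and the compounds carrying it hold the two lowest numbers of the series, with no compound shown going against this. The reading for compound 4 is a limit of the assay and not a number: the limit of > 50000 nM in this assay, at which 1 of the 4 values shown sits.

As far as these compounds go, what stays open is which part of the change matters, since a single step both removes 2-aminoethyl and brings in a six-membered aromatic ring carrying trifluoromethoxy. An unsubstituted phenyl, a 4-aminophenyl or a longer aminoalkyl chain on the same nitrogen would separate these parts, and a carboxylic acid at the end of the chain would test whether the terminal amine can be replaced at all.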